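Halogen swap on the aryl ketone: compound 2 to compound 3

A few compounds are considered here, and "the series" means these few. Any claim that something is new, unique, unknown or untested is made for them only; others in the source may bear on it.

The series keeps a shared core and varies the aryl group on the carbonyl. Compound 1 `O=C(/C=C/c1ccc2c(c1)B(O)OC2)c1cccs1` carries thiophen-2-yl; in a functional assay on MDA-MB-231 cells (Homo sapiens) for cytotoxicity, read by MTT assay, with a stated time of 48 h (a lower number here means a stronger inhibitor, a higher number a weaker inhibitor), compound 1 gives 4600 nM. Compound 2 `O=C(/C=C/c1ccc2c(c1)B(O)OC2)c1ccc(F)cc1` carries 4-fluorophenyl instead, and in this assay compound 2 gives 1600 nM, the lower of the two numbers; that exchange gave a 2.9-fold lower number from compound 1 to compound 2 (0.46 log units; beyond the scatter). Compound 3 `O=C(/C=C/c1ccc2c(c1)B(O)OC2)c1ccc(I)cc1` is the next step: iodo in place of fluoro on an aromatic carbon. Going by the values given here, no measured pair addresses a fluoro-to-iodo exchange on its own; the only step available, a 2.9-fold lower number from compound 1 to compound 2 (0.46 log units; beyond the scatter), swaps the whole aryl group and does not separate the halogen from the ring it sits on. The expectation for compound 3 in this assay is therefore a step of about a 1.2-fold lower number from compound 2 to compound 3 (0.09 log units; within the scatter), which would not clear the scatter. Compound 3 is estimated at 1300 nM in this assay, with a range of 500 nM to 4000 nM.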

Compound 3, half-maximal inhibitory concentration: 14900 nM
For compound 3 the middle estimate is 11-fold (1.06 log units) below the measured one, and the stated range ends below it.
By their numbers in this assay, from the lowest: compound 2; then compound 1; then compound 3.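

In this assay the identity of the halogen on this aromatic carbon carries weight on its own, with a 9.3-fold higher number from compound 2 to compound 3 (0.97 log units; beyond the scatter) for a single-atom exchange, something the earlier pair could not isolate. A phenyl ring in place of thiophen-2-yl does not by itself set the level: 4-fluorophenyl gave the lower number of that pair, while 4-iodophenyl lands on the other side, with a 3.2-fold higher number from compound 1 to compound 3 (0.51 log units; beyond the scatter) in the same assay. No measurement at hand bears on what lies behind these steps.

On these data alone, whether chloro or bromo on the same carbon would fall between fluoro and iodo, or would follow no such order, stays open. Unsubstituted phenyl, or an amine or a carboxylic acid at this position, would show whether a halogen is needed here at all.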